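Swapping phenyl for thiophen-2-yl at the tolerance limit

A few compounds are considered here, and "the series" means these few. Any claim that something is new, unique, unknown or untested is made for them only; others in the source may bear on it.

In an ADME assay on MRC5 cells (Homo sapiens) for cytotoxicity, read by MTT assay, with a stated time of 72 h (a higher number here means that more compound is tolerated, a lower number that less compound is tolerated), the three measured compounds give limits rather than exact numbers. Compound 1 `OC[C@H]1O[C@@H](n2cc(F)c3c(-c4ccccc4)ncnc32)[C@H](O)[C@@H]1O` gives > 50000 nM, a limit. Compound 2 `OC[C@H]1O[C@@H](n2cc(F)c3c(-c4c[nH]cn4)ncnc32)[C@H](O)[C@@H]1O` gives > 50000 nM, also a limit. Compound 3 `OC[C@H]1O[C@@H](n2cc(Cl)c3c(-c4ccccc4)ncnc32)[C@H](O)[C@@H]1O` gives > 50000 nM, again a limit. Together they show (the limit of > 50000 nM in this assay, at which 3 of the 3 values shown sit). Compound 4 `OC[C@H]1O[C@@H](n2cc(Cl)c3c(-c4cccs4)ncnc32)[C@H](O)[C@@H]1O` carries thiophen-2-yl in place of the phenyl of compound 3 on an aromatic carbon: thiophen-2-yl in place of phenyl on an aromatic carbon. Among the compounds with values here, two measured steps bear on this change: the ring swap a step that the two limits leave unreadable from compound 1 to compound 2 and the halogen swap a step that the two limits leave unreadable from compound 1 to compound 3. Neither has a readable size, so no step beyond the scatter is expected. The expected change is an at least 1.1-fold lower number from compound 3 to compound 4 (0.04 log units; that floor lies within the scatter). For compound 4, the estimated value is 45000 nM, within an expected range of 10000 nM to 60000 nM.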

Compound 4, half-maximal cytotoxic concentration: > 50000 nM
Compound 4 gave a limit, no number; the forecaster's own chance of this, stated with the estimate: 70%; at least 1.1-fold (0.04 log units) between middle value and limit.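

Compound 3 and compound 4 both sit at a limit, so the step from phenyl to thiophen-2-yl cannot be read: the limit of > 50000 nM in this assay, at which 4 of the 4 values shown sit. From the compounds shown here alone, the real numbers for compound 1, compound 2, compound 3 and compound 4 stay open, and so does any order among them.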